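The compounds below may be only part of what the source reports. "The series", "measured", "known", "first", "only" and "open" are said of these compounds alone.

In a functional assay on HeLa cells (Homo sapiens) for antiproliferative activity, read by MTT assay, with a stated time of 72 h (a lower number here means a stronger inhibitor, a higher number a weaker inhibitor), compound 1 `CCNC(=O)c1cc(Oc2ccc(NC(=O)c3nn(-c4ccccc4C)c(=O)cc3C)cc2)ccn1` gives 27300 nM. Within the data shown here, its close relative, compound 2 `CCCNC(=O)c1cc(Oc2ccc(NC(=O)c3nn(-c4ccccc4C)c(=O)cc3C)cc2F)ccn1`, gives 24600 nM, so the two numbers lie within the scatter of each other and compound 1 stands level with its only neighbour. Compound 3 `CCNC(=O)c1cc(Oc2ccc(NC(=O)c3nn(-c4cccc(C(F)(F)F)c4)c(=O)cc3C)cc2)ccn1` keeps the core of compound 1 but carries 3-(trifluoromethyl)phenyl in place of 2-methylphenyl on an aromatic nitrogen. Both measured compounds bear the 2-methylphenyl group, so the data contain no measured comparison at this place and offer only weak guidance. A small move toward a lower number seems the most reasonable guess, not clearly beyond the scatter. The expected change is a 1.7-fold lower number from compound 1 to compound 3 (0.23 log units; within the scatter). For compound 3 the estimated value is 16000 nM, with an expected range from 5000 nM to 45000 nM.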

Compound 3, half-maximal inhibitory concentration: 10700 nM
Compound 3: the middle estimate sits 1.5-fold (0.17 log units) above what was measured; measured number inside the range.
By their numbers in this assay, from the lowest: compound 3; then compounds 2 and 1 (each within the scatter of the next).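

This position on the aromatic nitrogen is now shown to matter. In this assay, putting 3-(trifluoromethyl)phenyl in place of 2-methylphenyl gives a 2.6-fold lower number from compound 1 to compound 3 (0.41 log units; beyond the scatter) and so moves the number by a modest step that clears the usual scatter, something compound 1 and compound 2 could not show while both carried 2-methylphenyl. No measurement is available that explains this shift.

The swap changes both the group on the phenyl ring and where that group sits, so these compounds cannot separate the two changes. A plain phenyl ring, or a phenyl ring carrying a chlorine atom or a methoxy group, would be needed to show how far the number follows the kind of group and how far its location on the ring.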